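From Free Acid to Ethyl Ester: A Cytotoxicity Step

The compounds below may be only part of what the source reports. "The series", "measured", "known", "first", "only" and "open" are said of these compounds alone.

Measured so far:
Compound 1, `Cc1nc(C)c(C(=O)Oc2ccc(/C=C/C(=O)O)cc2O)nc1C`: 285%
Compound 2, `CCOC(=O)/C=C/c1cc(Cl)ccc1OC(=O)c1nc(C)c(C)nc1C`: 33.7%
Compound 3, `COc1ccc(/C=C/C(=O)O)cc1OC(=O)c1nc(C)c(C)nc1C`: 160%

In a functional assay on EA.hy 926 cells (Homo sapiens) for cytotoxicity, read by MTT assay, with stated times of 24 h and 12 h, tested at 50 uM (on this read-out higher numbers stand for a stronger effect at the one concentration tested and lower numbers for a weaker effect), compound 3 gives 160%, the second highest of the three numbers. Compound 1 gives 285%, beyond the scatter above it, and compound 2 gives 33.7%, beyond the scatter below it. Compound 4, `CCOC(=O)/C=C/c1ccc(OC)c(OC(=O)c2nc(C)c(C)nc2C)c1`, has not yet been measured. It differs from compound 3 by ethyl in place of hydrogen on an oxygen next to a carbonyl group. Within the data shown here, compound 2 is the only measured compound that carries an ethoxycarbonyl group, and it stands lowest, but it differs from compound 3 in more than one place, so no single step can be read from it. A downward step beyond the scatter is nonetheless expected, a number 70 percentage points lower from compound 3 to compound 4 (beyond the scatter), because compound 2 gives 33.7%. For compound 4 the estimate is 90%, within 30% to 200%.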

Compound 4, a percentage reported as activity, at one concentration (the size of the read-out at that concentration, not a potency): 89%
For compound 4 the middle estimate is 1 percentage points above the measured one; the measured number falls inside the stated range.
By their numbers in this assay, from the lowest: compound 2; then compound 4; then compound 3; then compound 1.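

Within this assay the change from carboxy to ethoxycarbonyl gives a number 71 percentage points lower from compound 3 to compound 4 (beyond the scatter) and is the first change in a single place that can be read in this series. It shows that, with the rest of compound 3 kept, capping this acid as its ethyl ester lowers the read-out by a large step. Nothing shown accounts for this drop. As far as these compounds go, whether a methyl ester, a longer chain on that oxygen or an amide would give a similar step stays open. So does whether the same change would lower the read-out of compound 1.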